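From thiophen-2-yl to phenyl on a shared core

The source may hold more compounds than are shown below. What is called first, only, known or untested is meant among the compounds shown, and "the series" means these compounds.

Of the compounds shown here, two with one shared core have been measured so far. In a functional assay on NB-4 cells (Homo sapiens) for cytotoxicity, read by CCK-8 assay, with a stated time of 24 h (on this read-out lower numbers stand for stronger inhibition and higher numbers for weaker inhibition), compound 1 `C=CC(=O)N1C(=O)CC(c2ccccc2Cl)Sc2ccccc21` with its 2-chlorophenyl group gives 33800 nM while compound 2 `C=CC(=O)N1C(=O)CC(c2cccs2)Sc2ccccc21` gives 765000 nM and so holds the higher, weaker of the two numbers.

The next compound is compound 3 `C=CC(=O)N1C(=O)CC(c2ccccc2)Sc2ccccc21` with phenyl in place of thiophen-2-yl on a saturated ring carbon, next to the ring sulfur. The counted difference is phenyl in place of thiophen-2-yl on a saturated ring carbon and nothing else in the structure changes.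

Among the measured compounds shown here, the one measured step on that carbon is large, a 23-fold higher number from compound 1 to compound 2 (1.35 log units; beyond the scatter) on going to thiophen-2-yl from 2-chlorophenyl, and since compound 3 keeps the six-membered aromatic ring of carbon only found in compound 1, part of that step is expected to reverse. How much of it belongs to the chlorine, the data do not show. The estimated change is a 6.4-fold lower number from compound 2 to compound 3 (0.80 log units; beyond the scatter) toward a lower number, smaller than that measured step. In this assay the estimate for compound 3 is 120000 nM (expected range 30000 nM to 500000 nM).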

Compound 3, half-maximal inhibitory concentration: 35500 nM
Beside the measured number, compound 3's estimate is 3.4-fold (0.53 log units) above it, and the stated range covers the measured number.
By their numbers in this assay, from the lowest: compounds 1 and 3 (each within the scatter of the next); then compound 2.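

In this assay, phenyl in place of thiophen-2-yl on the saturated ring carbon, next to the ring sulfur, gives a 22-fold lower number from compound 2 to compound 3 (1.33 log units; beyond the scatter), so the large gap that first appeared between compound 1 and compound 2 is also present when no chlorine is involved. Hydrogen in place of chloro on the aromatic carbon gives a 1.1-fold higher number from compound 1 to compound 3 (0.02 log units; within the scatter), which means that in this pair the chloro group makes no difference that can be told from the usual scatter, and what separates compound 2 from the other two at this position is the thiophen-2-yl group itself. Nothing measured here explains why the five-membered aromatic ring with its sulfur stands apart from the two six-membered aromatic rings of carbon only.

The compounds shown leave open whether a pyridin-2-yl ring, or a phenyl ring carrying a methoxy group or an amine, would stay with compound 1 and compound 3 or move away from them. They also leave open how a saturated cyclohexyl ring on this carbon would compare with phenyl, and whether any group here can reach much lower numbers.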